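The compounds below may be only part of what the source reports. "The series", "measured", "known", "first", "only" and "open" are said of these compounds alone.

Measured so far:
compound 1, `CN(C)CCCNc1nc(-c2ccc(NC(=O)Nc3ccccc3F)cc2)nc2ccsc12`, 660 nM in a functional assay on MDA-MB-231 cells (Homo sapiens) for cytotoxicity, read by MTT assay, with a stated time of 72 h; on this read-out lower numbers stand for stronger inhibition and higher numbers for weaker inhibition
compound 2, `CN(C)CCNc1nc(-c2ccc(NC(=O)Nc3ccccc3)cc2)nc2ccsc12`, 1310 nM in this assay

Compound 2 carries the higher of the two numbers in this assay, yet its gap to compound 1 is within the scatter, so the two cannot be told apart on these measurements. Compound 3, `CN(C)CCNc1nc(-c2ccc(NC(=O)Nc3ccc(F)cc3)cc2)nc2ccsc12`, is the next compound and has not been measured. It differs from compound 2 in one place: fluoro in place of hydrogen on an aromatic carbon. Going by the values given here, no pair of measured compounds differs in this single way, so there is no measured step of this kind to lean on. Among the compounds with values here, with only two measured compounds and no step of this type, a change of this size is expected to stay within the scatter, in no particular direction. Compound 3 is therefore estimated at 1000 nM, within a range of 400 nM to 2500 nM. This estimate corresponds to a step of a 1.3-fold lower number from compound 2 to compound 3 (0.12 log units; within the scatter).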

Compound 3, half-maximal inhibitory concentration: 540 nM
The estimate for compound 3 lay 1.9-fold (0.27 log units) above the measured number; measured number inside the range.
By their numbers in this assay, from the lowest: compounds 3, 1 and 2 (each within the scatter of the next, the first and the last beyond it).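

Going from phenylcarbamoyl to (4-fluorophenyl)carbamoyl gives a 2.4-fold lower number from compound 2 to compound 3 (0.38 log units; beyond the scatter) in this assay, the first single-place comparison available in this set. This aromatic carbon, para to a large group, is therefore not indifferent to what it carries: one fluorine atom in place of a hydrogen is enough to give a modest but real move towards stronger inhibition. Nothing measured here says why the number moves with this change.

Still open, on these data alone, is whether this step is particular to fluoro, or whether a chloro, a methoxy or an amine on the same carbon would shift the number as well. Also open, as far as these compounds go, is whether the step would hold with a longer chain carrying the dimethylamino group.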